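The source may report more compounds than this note shows. Statements on the series, on what has been measured and on what is new or still open speak of the compounds shown alone.

Measured so far:
Compound 1, `CCCS(=O)(=O)Nc1ccc(F)c(C(=O)c2n[nH]c3ncc(-c4cccc(N(C)C)c4)cc23)c1F`, gives 26%.
Compound 2, `CCCS(=O)(=O)Nc1ccc(F)c(C(=O)c2n[nH]c3ncc(-c4cc(Cl)cc(Cl)c4)cc23)c1F`, gives 73%.

Both values come from an assay for binding affinity to dual specificity mitogen-activated protein kinase kinase 4 (Homo sapiens), read by KINOMEscan, tested at 100 nM; on this read-out lower numbers stand for a stronger effect and higher numbers for a weaker effect at the one concentration tested. Compound 2 stands at the highest of the two numbers, so it shows the weaker effect of the pair. Going by the values given here, the one measured step, a number 47 percentage points higher from compound 1 to compound 2 (beyond the scatter), involved the same attachment point that changes here: swapping the group on the ring carbon two atoms from the ring nitrogen of the shared core. Compound 3, `CCCS(=O)(=O)Nc1ccc(F)c(C(=O)c2n[nH]c3ncc(-c4ccc(NS(C)(=O)=O)cc4)cc23)c1F`, carries the change (4-(methanesulfonamido)phenyl in place of 3,5-dichlorophenyl on an aromatic carbon). As with compound 1, a nitrogen-bearing substituent returns to this position, and in compound 1 that arrangement gave 26%, so a step back toward lower numbers is expected, though the new group differs from either measured one and the size is uncertain. Compound 3 is therefore estimated at 40%, within 15% to 75%, an expected step of a number 33 percentage points lower from compound 2 to compound 3 (beyond the scatter).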

Compound 3, a percentage reported as activity, at one concentration (the size of the read-out at that concentration, not a potency): 0.85%
Compound 3: middle estimate off by 39.2 percentage points, on the high side; the whole stated range lies above it.
By their numbers in this assay, from the lowest: compound 3; then compound 1; then compound 2.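

In this assay, this position turns out to allow a much stronger effect than the first two compounds showed: the step is a number 72.2 percentage points lower from compound 2 to compound 3 (beyond the scatter) and marks the largest change seen here. The new group also beats the nitrogen-bearing group of compound 1, with a number 25.2 percentage points lower from compound 1 to compound 3 (beyond the scatter) giving compound 3 the lowest number of the three, so carrying a nitrogen is not the whole story, as these two nitrogen-bearing groups still differ clearly. No measurement at hand explains why these groups differ so much.

Compound 3 differs from compound 1 in both the substituent and its place on the phenyl ring, so those two changes cannot be separated. On these data alone, a 3-(methanesulfonamido)phenyl or 4-(dimethylamino)phenyl group would help to pull them apart, and how either would read remains open.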